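Carbonyl substituents on the shared core: working notes

The source may report more compounds than this note shows. Statements on the series, on what has been measured and on what is new or still open speak of the compounds shown alone.

Measured in an ADME assay on L6 cells (Rattus norvegicus) for cytotoxicity, read by resazurin assay, with a stated time of 70 h; on this read-out lower numbers stand for stronger inhibition and higher numbers for weaker inhibition:
- compound 1 `CC(=O)Oc1ccc2c(c1)C(C)=CC(C)(C)N2Cc1ccccc1`: 24000 nM
- compound 2 `CC1=CC(C)(C)N(Cc2ccccc2)c2ccc(OC(=O)C(C)(C)C)cc21`: 170000 nM

Of the two numbers, that of compound 2 is the higher. Compound 3 `CCCCCCCC(=O)Oc1ccc2c(c1)C(C)=CC(C)(C)N2Cc1ccccc1` differs from compound 2 by heptyl in place of tert-butyl on a carbonyl carbon. Going by the values given here, one measured step bears on this: a 7.1-fold higher number from compound 1 to compound 2 (0.85 log units; beyond the scatter), tert-butyl in place of methyl, modest and beyond the scatter. Among the compounds with values here, no heptyl compound has been measured, so the guidance is weak. Removing tert-butyl is expected to give a lower number in this assay, of similar modest size. The expected step is a 4.3-fold lower number from compound 2 to compound 3 (0.63 log units; beyond the scatter). For compound 3 the estimate is 40000 nM, with an expected range of 10000 nM to 150000 nM.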

Compound 3, half-maximal inhibitory concentration: 220000 nM
For compound 3 the middle estimate is 5.5-fold (0.74 log units) below the measured one, and the stated range ends below it.
By their numbers in this assay, from the lowest: compound 1; then compounds 2 and 3 (each within the scatter of the next).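

In this assay, heptyl and tert-butyl on this carbonyl carbon cannot be told apart, with a 1.3-fold higher number from compound 2 to compound 3 (0.11 log units; within the scatter). Set against methyl, the straight heptyl chain gives a 9.2-fold higher number from compound 1 to compound 3 (0.96 log units; beyond the scatter), so both larger groups part from compound 1 by a modest step beyond the scatter. No measured evidence accounts for this. Still open, going by these compounds, is how an ethyl or a phenyl group on this carbonyl carbon would read. Also open, on these data alone, is whether an amine at the end of the chain would leave the number near that of compound 3.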